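Swapping Cyclopentyl for Isobutyl on a Microsomal Stability Series

The source may report more compounds than this note shows. Statements on the series, on what has been measured and on what is new or still open speak of the compounds shown alone.

Compound 1 `Cc1ccc(C(=O)Nc2cc3nncn3c(CN3CCN(C(=O)C4CCCC4)[C@@H](C)C3)c2C)cn1`: 59 mL.min-1.g-1
Compound 2 `Cc1ccc(C(=O)Nc2cn3ncnc3c(CN3CCN(C(=O)C4CCCC4)[C@@H](C)C3)c2C)cn1`: 32 mL.min-1.g-1
Compound 3 `Cc1ccc(C(=O)Nc2cc(F)cc(CN3CCN(C(=O)C4CCCC4)[C@@H](C)C3)c2C)cn1`: 88 mL.min-1.g-1

In an ADME assay on microsomes from liver (Homo sapiens) for metabolic stability (a lower number here means slower removal, a higher number faster removal of the compound), compound 2 gives 32 mL.min-1.g-1, the smallest of the three numbers. Compound 1 sits close to it, at a distance inside the scatter, so these two cannot be told apart. Compound 3, at 88 mL.min-1.g-1, is cleared faster than compound 2, a gap beyond the scatter. Compound 4 `Cc1ccc(C(=O)Nc2cn3ncnc3c(CN3CCN(C(=O)CC(C)C)[C@@H](C)C3)c2C)cn1` keeps the core of compound 2 and changes one group: isobutyl in place of cyclopentyl on a carbonyl carbon. Within the data shown here, no measured pair shows what this change does in this assay. The expected step from compound 2 to compound 4 is therefore small, a 1.2-fold higher number from compound 2 to compound 4 (0.07 log units; within the scatter), not beyond the scatter in either direction. Compound 4 is estimated at 38 mL.min-1.g-1, ranging from 18 mL.min-1.g-1 to 80 mL.min-1.g-1.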

Compound 4, intrinsic clearance in microsomes: 20 mL.min-1.g-1
The estimate for compound 4 lay 1.9-fold (0.28 log units) above the measured number; the measured number falls inside the stated range.
By their numbers in this assay, from the lowest: compounds 4, 2, 1 and 3 (each within the scatter of the next, the first and the last beyond it).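

On the carbonyl carbon bonded to the amide-type ring nitrogen, swapping cyclopentyl for isobutyl in this assay gives a 1.6-fold lower number from compound 2 to compound 4 (0.20 log units; within the scatter). The ring can therefore be given up here, on the core of compound 2, without a change that can be told from the scatter. No measurement shown here accounts for this result.

Going by these compounds, whether a longer chain or an amine at this position would shift the number beyond the scatter remains open. So does whether this swap gives a similar step on the cores of compound 1 and compound 3.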